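The compounds below may be only part of what the source reports. "The series", "measured", "known", "first", "only" and "open" are said of these compounds alone.

In a functional assay on HCT-15 cells (Homo sapiens) for antiproliferative activity, read by MTT assay, with a stated time of 72 h (on this read-out lower numbers stand for stronger inhibition and higher numbers for weaker inhibition), compound 1 `CCCCn1ccnc1-c1cc(OC)c(OC)c(OC)c1` reads > 100000 nM, a limit and not a number. Compound 2 `COc1cc(-c2nccn2S(=O)(=O)c2ccccc2)cc(OC)c1OC` reads > 100000 nM, also a limit. Compound 3 `COc1cc(-c2nccn2-c2cccc([N+](=O)[O-])c2)cc(OC)c1OC` reads > 100000 nM, again a limit. Going by the values given here, compound 1 therefore stands at the limit of > 100000 nM in this assay, at which 3 of the 3 values shown sit, and no measured step is available. The next compound is compound 4 `COc1cc(-c2nccn2-c2ccc(F)cc2)cc(OC)c1OC`, with 4-fluorophenyl in place of butyl on an aromatic nitrogen. The expectation rests on compound 3, which also has an aromatic ring on that nitrogen and still reads > 100000 nM as a limit. The expected step of an at least 1.6-fold lower number from compound 1 to compound 4 (0.22 log units; that floor lies within the scatter) is small, towards stronger inhibition if any. For compound 4 the estimated value is 60000 nM, with an expected range of 15000 nM to 100000 nM.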

Compound 4, half-maximal inhibitory concentration: 68600 nM
The estimate for compound 4 lay 1.1-fold (0.06 log units) below the measured number, and the stated range covers the measured number.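

With 4-fluorophenyl in place of butyl on the aromatic nitrogen, compound 4 is the only compound shown in this assay that gives a number and not a limit. The step is an at least 1.4-fold lower number from compound 1 to compound 4 (0.16 log units; that floor lies within the scatter); only this floor is known, so the change is not shown to give a real gain. The rest of the series stays at the limit: the limit of > 100000 nM in this assay, at which 3 of the 4 values shown sit.

Going by these compounds, whether an unsubstituted phenyl or a benzyl on this nitrogen also gives a number stays open. So does whether an aminoalkyl chain or a carboxylic acid there gives a lower one.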